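Compound 1 loses its propanoylamino group to nitro

The compounds below may be only part of what the source reports. "The series", "measured", "known", "first", "only" and "open" are said of these compounds alone.

In a toxicity assay on Huh-7.5 cells (Homo sapiens) for inhibition, read by MTT assay, with a stated time of 96 h (a lower number here means that less compound is tolerated, a higher number that more compound is tolerated), compound 1 (`CCC(=O)Nc1cc(C(=O)Nc2ccc(CN3CCN(C)CC3)c(C(F)(F)F)c2)ccc1OC(C)C`) gives 15300 nM as the lowest of the three measured numbers. Compound 2 (`CCC(=O)Nc1cc(C(=O)Nc2ccc(CN3CCN(C)CC3)c(C(F)(F)F)c2)ccc1OC`) stands at 35300 nM and compound 3 (`COc1ccc(NC(=O)c2ccc3c(c2)NC(=O)CO3)cc1`) at 77300 nM on the same scale. Compound 4 (`CC(C)Oc1ccc(C(=O)Nc2ccc(CN3CCN(C)CC3)c(C(F)(F)F)c2)cc1[N+](=O)[O-]`) has not yet been measured. It carries nitro in place of propanoylamino on an aromatic carbon, ortho to an isopropoxy group and meta to a large group (nitro in place of propanoylamino on an aromatic carbon). For the measured compounds named here, only one measured step bears on this change, and only indirectly: a 2.3-fold higher number from compound 1 to compound 2 (0.36 log units; beyond the scatter) is a modest move for methyl in place of isopropyl on an oxygen, and it leaves the propanoylamino group untouched. Going by the values given here, no measured compound shows what replacing that group does, so a step of similar modest size is the most the data can suggest, and no step beyond the scatter is anticipated. In this assay the expected change is a 1.3-fold lower number from compound 1 to compound 4 (0.11 log units; within the scatter) with only a slight lean in that direction. Compound 4 is estimated at 12000 nM and expected to fall between 5000 nM and 30000 nM.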

Compound 4, half-maximal cytotoxic concentration: 3500 nM
Compound 4: middle estimate off by 3.4-fold (0.54 log units), on the high side, outside the stated range (below it).
By their numbers in this assay, from the lowest: compound 4; then compound 1; then compound 2; then compound 3.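

In this assay, the aromatic carbon ortho to an isopropoxy group proves to be a place where the substituent counts: a 4.4-fold lower number from compound 1 to compound 4 (0.64 log units; beyond the scatter) when nitro stands in place of propanoylamino. For the compounds shown here, compounds 1 and 2 had varied only the group on the oxygen, so this is the first measured step at this position, and it runs toward less compound being tolerated. Nothing measured here accounts for the shift.

The compounds shown leave open whether the step follows from the loss of propanoylamino or from the arrival of nitro, as this one change exchanges both at once. A plain amine or an acetylamino group on the same carbon, or nitro paired with methoxy on the oxygen, would help to separate the two readings.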